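The source may report more compounds than this note shows. Statements on the series, on what has been measured and on what is new or still open speak of the compounds shown alone.

- compound 1 `Nc1nc2ccnc(-c3cccc(C(F)(F)F)c3)n2n1` gives 166 mg/kg
- compound 2 `Nc1nc2ccnc(-c3ccncc3)n2n1` gives 14 mg/kg
- compound 3 `Nc1nc2ccnc(-c3ccc(F)cc3)n2n1` gives 178 mg/kg

In a functional assay on the whole organism with Mus musculus as the target (on this read-out higher numbers stand for an effect only at larger amounts of compound and lower numbers for an effect already at smaller amounts), the number for compound 1 lies within the scatter of compound 3, and beyond the scatter above compound 2. Compound 4 `Nc1nc2ccnc(-c3cccc(Br)c3)n2n1` differs from compound 1 at one place: bromo in place of trifluoromethyl on an aromatic carbon, meta to a large group (bromo in place of trifluoromethyl on an aromatic carbon). Within the data shown here, no measured pair differs at one place only, so no measured step guides this change. Compound 1 at 166 mg/kg and compound 3 at 178 mg/kg stay within the scatter of each other, and compound 4 keeps the six-membered aromatic ring of carbon only. Among the measured compounds shown here, compound 2 at 14 mg/kg is the one number far from these two, and it goes against any reading of the series as flat. In this assay no change beyond the scatter is expected for this replacement. The expected step is a 1.3-fold lower number from compound 1 to compound 4 (0.11 log units; within the scatter) and it is estimated to stay within the scatter. For compound 4 the estimated value is 130 mg/kg with an expected range from 55 mg/kg to 300 mg/kg.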

Compound 4, dose for half-maximal effect: 142 mg/kg
Estimate against measurement, compound 4: 1.1-fold (0.04 log units) below; low and high end bracket the measured number.
By their numbers in this assay, from the lowest: compound 2; then compounds 4, 1 and 3 (each within the scatter of the next).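

In this assay, among these compounds, bromo in place of trifluoromethyl gives a 1.2-fold lower number from compound 1 to compound 4 (0.07 log units; within the scatter), the first comparison between compounds that differ in one place only. On an aromatic carbon, meta to a large group, a group of 1 heavy atom can thus stand in place of one of 4 heavy atoms without a change beyond the scatter. This read-out therefore does not separate these two groups at this place, and nothing at hand gives a reason for that.

From the compounds shown here alone, whether an amine, a carboxylic acid or a longer chain at this place would also stay within the scatter remains open. Also open, going by these compounds, is whether the same replacement would give a comparable step on another aromatic carbon of compound 1.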